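The source may hold more compounds than are shown below. What is called first, only, known or untested is meant among the compounds shown, and "the series" means these compounds.

Measured in a functional assay on HT-22 cells (Mus musculus), read by MTT assay, with a stated time of 24 h; a lower number here means that less compound is needed, a higher number that more compound is needed for the effect:

Compound 1 `COc1cc(-c2ccc(O)c(O)c2)nc2ccccc12`: 40 nM
Compound 2 `COc1cc(-c2ccc(O)cc2)nc2ccccc12`: "not active" (no number reported)

Compound 2 has no number to stand on. It was reported only as "not active" (no number reported), so the size of any change starting from it cannot be calculated. Compound 3 `COc1cc(-c2ccc(O)cc2O)nc2ccccc12` has not yet been measured. The change is hydroxy in place of hydrogen on an aromatic carbon: a hydroxy group replaces a hydrogen on an aromatic carbon of a six-membered aromatic ring of carbon only, ortho to a large group and meta to a hydroxy group.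

Among the compounds with values here, no measured pair shows what this exact change does, so any expectation is loose. The expected direction is from no reported number to a measurable one, although the size of that step cannot be stated and compound 3 may also prove inactive. The closest guide is compound 1, with its 40 nM, which shows that a compound of this kind can work in this assay. Compound 3 is not expected to match it with any certainty. For compound 3 the estimated value is 300 nM, with an expected range from 30 nM to 3000 nM.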

Compound 3, half-maximal effective concentration: > 500 nM
Compound 3: a limit, no number; the forecaster's own chance of this, stated with the estimate: 45%; middle value at least 1.6-fold (0.22 log units) away from the limit.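

No step can be read from compound 2 to compound 3, because compound 2 was reported only as "not active" and compound 3 carries a limit rather than a number: the limit of > 500 nM in this assay, at which 1 of the 3 values shown sits. The compounds shown leave open whether the added hydroxy group of compound 3 changes the concentration needed in this assay at all, and by how much.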